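Swapping a pyridine for a pyrazine on the amide

The source may report more compounds than this note shows. Statements on the series, on what has been measured and on what is new or still open speak of the compounds shown alone.

Compound 1 `COc1ccc(Cn2c(CCc3ccccc3)nnc2[C@H](NC(=O)c2ccncc2)c2c[nH]c3ccccc23)c(OC)c1` is the only one of this small series with a result: in a functional assay on CHO cells for antagonist activity at growth hormone secretagogue receptor type 1 (Homo sapiens) (on this read-out lower numbers stand for stronger inhibition and higher numbers for weaker inhibition), compound 1 gives 93 nM. Compound 2 `COc1ccc(Cn2c(CCc3ccccc3)nnc2[C@H](NC(=O)c2ccncc2)c2c[nH]c3ccccc23)cc1` shares the same core, but in this assay compound 2 gives "not determined" (no result reported), so it cannot be placed on the scale. Compound 3 `COc1ccc(Cn2c(CCc3ccccc3)nnc2[C@H](NC(=O)c2cnccn2)c2c[nH]c3ccccc23)cc1` differs from compound 2 in one place (pyrazin-2-yl in place of pyridin-4-yl on a carbonyl carbon). Without a measured step involving compound 2, no direction can be read from the data, and the change is expected to produce at most a shift of about the size of the usual scatter, in either direction. Compound 3 is estimated at 150 nM in this assay, within 40 nM to 600 nM.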

Compound 3, antagonist equilibrium constant: 530 nM
The estimate for compound 3 lay 3.5-fold (0.55 log units) below the measured number; the range from low to high includes it.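

Among the compounds shown here, with no number for compound 2 in this assay no step to compound 3 can be read. No data shown bear on the result for compound 3. Going by these compounds, whether pyrazin-2-yl in place of pyridin-4-yl strengthens or weakens inhibition stays open.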